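This account rests on a few compounds, and the source may have more. Where it says the series, first, only, none or still open, it means among the compounds named here.

Compound 1, with structure `COC(=O)c1ccc(NCc2cncn2Cc2ccccc2Cl)cc1-c1ccccc1`, was tested in a toxicity assay on NIH3T3 cells (Mus musculus) for cytotoxicity, read by resazurin assay (a higher number here means that more compound is needed for the effect, a lower number that less compound is needed), and gives 10000 nM. Compound 2, `c1ccc(-c2ccc(Cn3cncc3CNc3cccc(-c4ccccc4)c3)cc2)cc1`, gives 10000 nM in this assay, so compound 1 stands level with compound 2 at the digits shown, within the scatter. Compound 3, `CC(C)c1ccc(Cn2cncc2CNc2ccc(-c3nc4ccccc4s3)c(-c3ccccc3)c2)cc1`, reached only a limit of the assay, > 1000 nM, in this assay; this is the limit of > 1000 nM in this assay, at which 1 of the 3 values shown sits. Among the measured compounds shown here, no step between measured compounds that differ in one place is available, so no measured size of effect can be quoted.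

Compound 4, `COC(=O)c1ccc(NCc2cncn2Cc2ccc(C#N)cc2)cc1-c1ccccc1`, is not yet measured in this assay. It differs from compound 1 by one change: 4-cyanophenyl in place of 2-chlorophenyl on a saturated chain carbon bound to an aromatic nitrogen. Since compound 1 gives 10000 nM and compound 2 gives 10000 nM despite quite different substituents, the expectation is that the step from compound 1 to compound 4 in this assay is small, not beyond the scatter, in either direction, estimated as no change at the digits printed from compound 1 to compound 4 (within the scatter). On that basis, compound 4 is expected to give 10000 nM in this assay, within a range from 4000 nM to 25000 nM.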

Compound 4, half-maximal effective concentration: > 10000 nM
Compound 4 ended at the assay's limit; the forecaster's own chance of this, stated with the estimate: 40%; the middle value sits exactly at the limit.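

In this assay, 4-cyanophenyl in place of 2-chlorophenyl on a saturated chain carbon bound to an aromatic nitrogen gives a number no lower from compound 1 to compound 4 (the limit leaves the size open). Compound 4 gives > 10000 nM, which is a limit of the assay and not a number, so the size of this step cannot be read: the limit of > 10000 nM in this assay, at which 1 of the 4 values shown sits. Among the compounds shown here, this is the first step measured at this position, and it shows that changing 2-chlorobenzyl to 4-cyanobenzyl, which brings in a nitrile, does not give a lower number.

The compounds shown leave open how far compound 4 lies from compound 1, and whether any group at this position gives a lower number in this assay. As far as these compounds go, a benzyl group carrying an amine or a carboxylic acid in place of the nitrile remains untested here.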